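The source may report more compounds than this note shows. Statements on the series, on what has been measured and on what is new or still open speak of the compounds shown alone.

Measured so far in a functional assay on K562 cells (Homo sapiens) for cytotoxicity, in the presence of a further agent that is not named here (on this read-out higher numbers stand for weaker inhibition and lower numbers for stronger inhibition), are these compounds:
compound 1 `Clc1ccc(-c2cc(-c3ccc(Cl)o3)cc(-c3ccsc3)n2)cc1` gives 18700 nM
compound 2 `Clc1ccc(-c2cc(-c3ccoc3)cc(-c3ccsc3)n2)cc1` gives 730 nM
compound 3 `Clc1ccc(-c2cc(-c3ccc(Cl)o3)cc(-c3cccs3)n2)cc1` gives 20900 nM

The value of compound 1 lies at the weak end of this small set. Its nearest step is a 1.1-fold higher number from compound 1 to compound 3 (0.05 log units; within the scatter) and its furthest is a 26-fold lower number from compound 1 to compound 2 (1.41 log units; beyond the scatter) in the same read-out.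

Compound 4 `Clc1cccc(-c2cc(-c3ccc(Cl)o3)cc(-c3ccsc3)n2)c1` carries the change 3-chlorophenyl in place of 4-chlorophenyl on an aromatic carbon as 3-chlorophenyl in place of 4-chlorophenyl, next to the ring nitrogen. Within the data shown here, no measured step touches this group. The closest in kind is thiophen-2-yl in place of thiophen-3-yl, which gave a 1.1-fold higher number from compound 1 to compound 3 (0.05 log units; within the scatter) on this scale. The large step of a 26-fold lower number from compound 1 to compound 2 (1.41 log units; beyond the scatter) belongs to the furan group and is a poor guide here. The expected step in this assay is therefore a 1.3-fold lower number from compound 1 to compound 4 (0.13 log units; within the scatter) with no firm direction. For compound 4 the estimated value is 14000 nM with an expected range from 4500 nM to 40000 nM in this read-out.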

Compound 4, half-maximal inhibitory concentration: 23000 nM
The estimate for compound 4 lay 1.6-fold (0.22 log units) below the measured number; the range from low to high includes it.
By their numbers in this assay, from the lowest: compound 2; then compounds 1, 3 and 4 (each within the scatter of the next).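

In this assay, 3-chlorophenyl in place of 4-chlorophenyl, next to the ring nitrogen, gives a 1.2-fold higher number from compound 1 to compound 4 (0.09 log units; within the scatter). Among these compounds, this is the first reading at this position, and the chlorine's placement on the phenyl ring shows no effect beyond the scatter, though only alongside 5-chlorofuran-2-yl and thiophen-3-yl. Nothing on hand offers an explanation for this result.

From the compounds shown here alone, whether the swap stays as small alongside the furan-3-yl group of compound 2 remains open. So does the effect of replacing the chlorine on this phenyl group with an amine or a carboxylic acid.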